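Permeability notes on the sulfonamide series

The source may hold more compounds than are shown below. What is called first, only, known or untested is meant among the compounds shown, and "the series" means these compounds.

Measured so far in an ADME assay on Caco-2 cells (Homo sapiens) for permeability, in the apical to basolateral direction; a higher number here means that the compound crosses the layer faster, a lower number that the compound crosses the layer more slowly:
compound 1, `Cn1cncc1CN1CC(N(CC2CCN(C(=O)C3CC3)CC2)S(=O)(=O)c2ccccn2)Cc2cc(C#N)ccc21`, 0.5 10^-6 cm/s
compound 2, `Cn1cncc1CN1CC(N(CC2CCN(C(=O)N3CCCC3)CC2)S(=O)(=O)c2ccccn2)Cc2cc(C#N)ccc21`, 0.6 10^-6 cm/s

Compound 2 stands highest of the two numbers, yet the step of a 1.2-fold higher number from compound 1 to compound 2 (0.08 log units; within the scatter) is within the scatter, so compound 1 and compound 2 cannot be told apart on this assay.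

Compound 3, `Cn1cnc(S(=O)(=O)N2CCC(CN(C3Cc4cc(C#N)ccc4N(Cc4cncn4C)C3)S(=O)(=O)c3ccccn3)CC2)c1`, has not been measured. Change against compound 2: (1-methyl-1H-imidazol-4-yl)sulfonyl in place of (pyrrolidin-1-yl)carbonyl on an amine nitrogen in a ring

Among the measured compounds shown here, only one measured step exists, a 1.2-fold higher number from compound 1 to compound 2 (0.08 log units; within the scatter), and it swaps one carbonyl substituent for another; it does not touch the carbonyl itself and so bears only loosely on a change that removes the (pyrrolidin-1-yl)carbonyl and brings in the (1-methyl-1H-imidazol-4-yl)sulfonyl. For the measured compounds named here, no measured pair in this set tests that kind of exchange. The expectation for compound 3 in this assay is therefore uncertain, with the step of a 1.5-fold lower number from compound 2 to compound 3 (0.18 log units; within the scatter) expected to stay small or to run modestly downward. Compound 3 is estimated at 0.4 10^-6 cm/s, with a range of 0.15 10^-6 cm/s to 1 10^-6 cm/s.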

Compound 3, apparent permeability: 0.1 10^-6 cm/s
For compound 3 the middle estimate is 4.0-fold (0.60 log units) above the measured one; measured number outside the range, below it.
By their numbers in this assay, from the lowest: compound 3; then compounds 1 and 2 (each within the scatter of the next).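

At the amine nitrogen in a ring, the exchange of a carbonyl group for (1-methyl-1H-imidazol-4-yl)sulfonyl gives, in this assay, a 6.0-fold lower number from compound 2 to compound 3 (0.78 log units; beyond the scatter) and a 5.0-fold lower number from compound 1 to compound 3 (0.70 log units; beyond the scatter) against the cyclopropylcarbonyl group. This position is therefore not neutral in this assay: the earlier swap between two carbonyl substituents stayed within the scatter, while both steps to the sulfonyl group lie beyond it, and compound 3 stands lowest of the three. No supporting measurement in hand accounts for the drop.

The sulfonyl link and the 1-methylimidazole ring enter together, so the compounds shown do not say which of the two goes with the step. A methylsulfonyl group or a (1-methyl-1H-imidazol-4-yl)carbonyl group on the same nitrogen would separate them.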